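Amino in Place of Hydrogen on Two Chloromethylbenzyl Cores

The source may hold more compounds than are shown below. What is called first, only, known or untested is meant among the compounds shown, and "the series" means these compounds.

Compound 1 `ClCc1ccc(Cn2cnc3c(Cl)ncnc32)cc1` and compound 3 `ClCc1ccccc1Cn1cnc2c(Cl)ncnc21` share the same atoms joined differently; the difference between the two cores is not broken down here. In a functional assay on SF-268 cells (Homo sapiens) for cytotoxicity, read by sulforhodamine B assay, with a stated time of 48 h (on this read-out higher numbers stand for weaker inhibition of growth and lower numbers for stronger inhibition of growth), compound 1 gives 2880 nM, while compound 3 gives 10900 nM. Compound 2 `Nc1nc(Cl)c2ncn(Cc3ccc(CCl)cc3)c2n1` carries the change amino in place of hydrogen on an aromatic carbon and in this assay compound 2 gives 8320 nM, so that a 2.9-fold higher number from compound 1 to compound 2 (0.46 log units; beyond the scatter). Compound 4 `Nc1nc(Cl)c2ncn(Cc3ccccc3CCl)c2n1` is the unmeasured partner of compound 3 and differs from it by amino in place of hydrogen on an aromatic carbon, the same change made on the other core. Going by the values given here, since the only measured instance of this change, a 2.9-fold higher number from compound 1 to compound 2 (0.46 log units; beyond the scatter), weakened growth inhibition modestly, a similar step is expected for compound 4, a 2.6-fold higher number from compound 3 to compound 4 (0.41 log units; beyond the scatter), though one such pair gives limited footing. In this assay compound 4 is therefore estimated at 28000 nM, between 12000 nM and 70000 nM.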

Compound 4, concentration for total growth inhibition: 14500 nM
Estimate against measurement, compound 4: 1.9-fold (0.29 log units) above; the range from low to high includes it.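

In this assay, amino in place of hydrogen on an aromatic carbon of the second core gives a 1.3-fold higher number from compound 3 to compound 4 (0.12 log units; within the scatter), so on this core the change leaves no clear mark. Set beside the earlier step, the result on this core does not differ measurably from it: the same change on two cores in this assay, a 2.9-fold higher number (0.46 log units; beyond the scatter) from compound 1 to compound 2 and a 1.3-fold higher number (0.12 log units; within the scatter) from compound 3 to compound 4, 2.2-fold (0.34 log units) apart, within the scatter of two such steps. The two cores are thus compatible with one shared effect, but two pairs cannot establish that the effect is the same size on both, nor that it would hold on any other core.

The compounds shown leave open how a methylamino or hydroxyl group on that aromatic carbon would behave. They also leave open what a methyl or hydroxymethyl group would do in place of the chloromethyl group.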